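A few compounds are considered here, and "the series" means these few. Any claim that something is new, unique, unknown or untested is made for them only; others in the source may bear on it.

Compound 1 `CCCn1c(=O)c2nc(-c3nn[nH]n3)[nH]c2n(CCC)c1=O`: > 10000 nM. Compound 2 `CC1(Nc2ncnc3c2ncn3C2O[C@H](CO)[C@@H](O)[C@H]2O)CCCCC1`: 70 nM. Compound 3 `CCCn1c(=O)c2nc(-c3cc4ccccc4s3)[nH]c2n(CCC)c1=O`: > 100000 nM.

In an assay on cell membranes for binding affinity to adenosine receptor A1 (Cavia porcellus), read by radioligand binding (on this read-out lower numbers stand for stronger inhibition and higher numbers for weaker inhibition), compound 1 gives only > 10000 nM, which is a limit of the assay and not a number. Compound 2 gives 70 nM. Compound 3 also reaches only a limit, > 100000 nM. Compound 1 thus sits at the limit of > 10000 nM in this assay, at which 1 of the 3 values shown sits, while one further value sits at the limit of > 100000 nM in this assay, at which 1 of the 3 values shown sits. Compound 4 `CCCn1c(=O)c2nc(-c3cccn3C)[nH]c2n(CCC)c1=O` has not yet been measured; it differs from compound 1 by 1-methyl-1H-pyrrol-2-yl in place of 2H-tetrazol-5-yl on an aromatic carbon. No measured pair here differs in a single place, so this step has no direct precedent among these compounds. A gain beyond the scatter is expected, though with little certainty: compound 4 is estimated at 1500 nM, between 150 nM and 15000 nM, a step of an at least 6.6-fold lower number from compound 1 to compound 4 (0.82 log units; beyond the scatter).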

Compound 4, inhibition constant: 140 nM
Beside the measured number, compound 4's estimate is 11-fold (1.03 log units) above it, outside the stated range (below it).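

This aromatic carbon of the shared core matters for binding: in this assay, 1-methyl-1H-pyrrol-2-yl in place of 2H-tetrazol-5-yl gives an at least 71-fold lower number from compound 1 to compound 4 (1.85 log units; beyond the scatter). That size is only a lower bound, because the value of compound 1 is a limit: the limit of > 10000 nM in this assay, at which 1 of the 4 values shown sits. Compound 3, with another aromatic group at this place, also stays at a limit, > 100000 nM, so an aromatic ring there is not enough by itself.

A single step cannot separate the loss of the ring nitrogens, the loss of the hydrogen-bond donor and the added methyl. From the compounds shown here alone, how an amine or a carboxylic acid on this carbon would fare also remains open.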